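Carbamate ester variation on a shared core

The source may hold more compounds than are shown below. What is called first, only, known or untested is meant among the compounds shown, and "the series" means these compounds.

For the measured compounds named here, in a functional assay on isolated protein for inhibition of Glucose-dependent insulinotropic receptor (Homo sapiens), read by HTRF and cAMP accumulation (a higher number here means that more compound is needed for the effect, a lower number that less compound is needed), compound 2 `Cc1nc(S(C)(=O)=O)ccc1Oc1ncnc(OC2CCN(C(=O)OC(C)F)CC2)c1F` gives 65.5 nM, the lowest of the two numbers so far. Its nearest neighbour, compound 1 `Cc1nc(S(C)(=O)=O)ccc1Oc1ncnc(OC2CCN(C(=O)OC(C)(C)C#N)CC2)c1F`, gives 92.9 nM, and the step of a 1.4-fold lower number from compound 1 to compound 2 (0.15 log units; within the scatter) lies within the scatter. Compound 3 `Cc1nc(S(C)(=O)=O)ccc1Oc1ncnc(OC2CCN(C(=O)O[C@H](C)CF)CC2)c1F` carries 1-(fluoromethyl)ethyl in place of 1-fluoroethyl on an oxygen next to a carbonyl group. Going by the values given here, the only measured step at the oxygen next to a carbonyl group, a 1.4-fold lower number from compound 1 to compound 2 (0.15 log units; within the scatter), was small, so another exchange of a short fluorinated group there is expected to shift this assay by no more than the scatter. The step of a 1.1-fold higher number from compound 2 to compound 3 (0.03 log units; within the scatter) is therefore expected to be slight. Compound 3 is estimated at 70 nM, between 35 nM and 140 nM.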

Compound 3, half-maximal effective concentration: 196 nM
Compound 3: middle estimate off by 2.8-fold (0.45 log units), on the low side; measured number outside the range, above it.
By their numbers in this assay, from the lowest: compounds 2 and 1 (each within the scatter of the next); then compound 3.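

At the oxygen next to a carbonyl group, the ester group can move the number beyond the scatter, which the first pair did not show: a 3.0-fold higher number from compound 2 to compound 3 (0.48 log units; beyond the scatter) and a 2.1-fold higher number from compound 1 to compound 3 (0.32 log units; beyond the scatter) in this assay. Exchanging one short fluorinated group for another is therefore not neutral at this position. Nothing measured here accounts for the shift. The compounds shown leave open whether the defined stereocentre of compound 3 has any part in it. They also leave open where a plain isopropyl group, without fluorine, would stand at this position.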